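This account rests on a few compounds, and the source may have more. Where it says the series, first, only, none or still open, it means among the compounds named here.

Working notes on the series. Compound 1 `Cc1ccc(C)c(C(=O)OC2CCN(C)CC2)c1` gives 12.5 mg/kg in a functional assay on the whole organism with Mus musculus as the target, in the hot plate test; a lower number here means that less compound is needed, a higher number that more compound is needed for the effect. Compound 2 `Cc1cccc(C)c1C(=O)OC1CCN(C)CC1` gives 15.2 mg/kg in this assay. Compound 1 stands on the lowest of the two numbers, but its gap to compound 2 lies within the scatter, so the two compounds read as a single level and no order between them is claimed. Both carry methyl groups on the aromatic ring of the shared core and share the same ester and the same saturated ring.

Compound 3 `Cc1cc(C)c(C(=O)OC2CCN(C)CC2)cc1C` remains to be measured in this assay. It differs from compound 1 by methyl in place of hydrogen on an aromatic carbon. Among the measured compounds shown here, no step between measured compounds covers this kind of change, so the expectation rests on the two measured values alone. Since compound 1 and compound 2 sit within the scatter of each other despite differently placed methyls, a further methyl is expected to leave the number roughly where compound 1 sits, with no step beyond the scatter in either direction. The step expected here is no change at the digits printed from compound 1 to compound 3 (within the scatter). Compound 3 is estimated at 12.5 mg/kg, with a range from 6 mg/kg to 26 mg/kg.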

Compound 3, dose for half-maximal effect: 20 mg/kg
Compound 3: the middle estimate sits 1.6-fold (0.20 log units) below what was measured, within the range that was stated.
By their numbers in this assay, from the lowest: compounds 1, 2 and 3 (each within the scatter of the next).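

In this assay, methyl in place of hydrogen on an aromatic carbon, at the place ortho to a methyl group, meta to a methyl group and para to a large group, comes with a 1.6-fold higher number from compound 1 to compound 3 (0.20 log units; within the scatter) and so stays within the scatter. Among the compounds shown here, this is the first change in a single place that can be read, and it shows that this position on the core of compound 1 takes a further methyl without a step beyond the scatter. No measurement of any property of these compounds bears on this result, and the step comes with no explanation.

The step speaks only for methyl at this one position, and the compounds shown carry nothing but methyl groups on the aromatic ring of the shared core. On these data alone, whether a methoxy group, a chlorine atom or an amine at the same place would also stay within the scatter of compound 1 remains open, as does the effect of a longer chain on the ring nitrogen in place of its methyl.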